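The compounds below may be only part of what the source reports. "The series", "measured", "known", "first", "only" and "open" are said of these compounds alone.

Measured compounds:
- compound 1 `O=S(=O)(Nc1ccc(Cl)c(F)c1)c1ccc(-c2cnc(C3CC3)o2)cc1`: 63000 nM
- compound 2 `O=S(=O)(Nc1cccc(Cl)c1)c1ccc(-c2cnc(C3CC3)o2)cc1`: 54200 nM
- compound 3 `Cc1ccc(NS(=O)(=O)c2ccc(-c3cnc(C4CC4)o3)cc2)cc1C`: > 100000 nM

All three compounds share one core and were tested in a functional assay on cells (leukaemia cell line, Homo sapiens) for inhibition, read by sulforhodamine B assay, with a stated time of 48 h; a higher number here means a weaker inhibitor of growth, a lower number a stronger inhibitor of growth. Compound 3 has no exact number, only a limit of the assay: > 100000 nM. This places compound 3 at the limit of > 100000 nM in this assay, at which 1 of the 3 values shown sits.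

The next compound, compound 4 `O=S(=O)(Nc1ccc(F)cc1F)c1ccc(-c2cnc(C3CC3)o2)cc1`, keeps the core and changes one group: 2,4-difluorophenyl in place of 3,4-dimethylphenyl on a sulfonamide nitrogen.

Among the measured compounds shown here, three measured steps concern this same place. Exchanging one halogen-bearing group for another gave a 1.2-fold lower number from compound 1 to compound 2 (0.07 log units; within the scatter). Moving to the 3,4-dimethylphenyl group gave an at least 1.5-fold higher number from compound 1 to compound 3 (0.20 log units; that floor lies within the scatter) and an at least 1.8-fold higher number from compound 2 to compound 3 (0.26 log units; that floor lies within the scatter). Neither of these last two steps shows a gap beyond the scatter, so the evidence for any effect of this group is weak.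

Compound 4 also carries a halogen-bearing group, so its number is expected to fall near those of compound 1 at 63000 nM and compound 2 at 54200 nM. Any expected shift from the limit of compound 3 is therefore a small one towards a lower number, and compound 4 may itself reach the limit.

For compound 4, the estimated value is 65000 nM, with an expected range from 35000 nM to 100000 nM.

This estimate means an expected at least 1.5-fold lower number from compound 3 to compound 4 (0.18 log units; that floor lies within the scatter).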

Compound 4, concentration for total growth inhibition: 66100 nM
Compound 4: the middle estimate sits 1.0-fold (0.01 log units) below what was measured; the measured number falls inside the stated range.
By their numbers in this assay, from the lowest: compounds 2, 1 and 4 (each within the scatter of the next). At a limit, above all of these: compound 3.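

Set against the other halogen-bearing groups on the sulfonamide nitrogen, the 2,4-difluorophenyl group gives a 1.2-fold higher number from compound 2 to compound 4 (0.09 log units; within the scatter) and a 1.0-fold higher number from compound 1 to compound 4 (0.02 log units; within the scatter), so in this assay these three halogen-bearing groups cannot be told apart, and a third such group now gives an exact number. Among the compounds shown here, exchanging the 3,4-dimethylphenyl group gives an at least 1.5-fold lower number from compound 3 to compound 4 (0.17 log units; that floor lies within the scatter), which is the first direct step between that group and the 2,4-difluorophenyl group, yet it still shows no gap beyond the scatter. Compound 3 remains a limit rather than a number, so the true size of this step stays unknown: the limit of > 100000 nM in this assay, at which 1 of the 4 values shown sits.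

The compounds shown leave open whether the halogens themselves matter, as neither a plain phenyl group nor a phenyl ring carrying an amine or a carboxylic acid stands among them. As far as these compounds go, the three exact values all lie within the scatter of one another, so it also stays open whether any group at this place can bring the number much lower.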